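Methoxy added on an already methoxylated sulfonamide core

This account rests on a few compounds, and the source may have more. Where it says the series, first, only, none or still open, it means among the compounds named here.

Measured so far:
compound 1, `COc1ccccc1-c1cccc(S(=O)(=O)N2CCC(N3CCC(C)CC3)CC2)c1`: > 5000 nM
compound 2, `COc1cccc(S(=O)(=O)N2CCC(N3CCC(C)CC3)CC2)c1`: > 5000 nM
compound 3, `CC1CCN(C2CCN(S(=O)(=O)c3cccc(-c4ccccc4)c3)CC2)CC1`: > 5000 nM

All three were tested in an ADME assay on HCT-116 cells (Homo sapiens) for cytotoxicity, read by CellTiter-Glo, with a stated time of 72 h; on this read-out lower numbers stand for stronger inhibition and higher numbers for weaker inhibition. For compound 1 the value is a limit of the assay, not a number. For compound 2 the value is likewise a limit. For compound 3 it is a limit as well, so that the limit of > 5000 nM in this assay, at which 3 of the 3 values shown sit, describes every value shown. Compound 1 differs from compound 3 by methoxy in place of hydrogen on an aromatic carbon, and that step, a step that the two limits leave unreadable from compound 3 to compound 1, cannot be read between two limits. Compound 2 differs from compound 3 by methoxy in place of phenyl on an aromatic carbon. Compound 4, `COc1ccc(OC)c(S(=O)(=O)N2CCC(N3CCC(C)CC3)CC2)c1`, awaits testing; it differs from compound 2 by methoxy in place of hydrogen on an aromatic carbon, the same kind of change as from compound 3 to compound 1, but here the place is also para to a methoxy group. With every shown value at the limit, the step from compound 2 to compound 4 is expected to be a step that the limit leaves unreadable from compound 2 to compound 4. Compound 4 is therefore estimated at 8000 nM, most likely again reported only as a limit.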

Compound 4, half-maximal inhibitory concentration: > 5000 nM
Compound 4 ended at the assay's limit; the forecaster's own chance of this, stated with the estimate: 85%; the middle value is on the limit's open side.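

Compound 2 and compound 4 each give a limit rather than a number, and no step can be read between them: the limit of > 5000 nM in this assay, at which 4 of the 4 values shown sit.

The compounds shown leave open how far past that limit any of them lies in this assay.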